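The compounds below may be only part of what the source reports. "The series", "measured", "known", "first", "only" and "open" are said of these compounds alone.

Among the measured compounds shown here, compound 2 `CN(C)c1ncnc2c1ncn2Cc1ccccc1F` is the only member of the series with a number in a functional assay on the whole organism with Rattus norvegicus as the target, in the maximal electroshock model (a lower number here means that less compound is needed, a higher number that more compound is needed for the effect), and compound 2 gives 8.8 mg/kg there. Compound 1 `CC(C)(C)Nc1ncnc2c1ncn2Cc1ccccc1F` gives only a limit in this assay, > 50 mg/kg. The remaining entry is thus (the limit of > 50 mg/kg in this assay, at which 1 of the 2 values shown sits). For the measured compounds named here, the single measured step, an at least 5.6-fold lower number from compound 1 to compound 2 (0.75 log units; beyond the scatter), is the only one that bears on the change under consideration. Compound 3 `Fc1ccccc1Cn1cnc2c(NC3CC3)ncnc21` differs from compound 2 by cyclopropylamino in place of dimethylamino on an aromatic carbon. The incoming cyclopropylamino restores the hydrogen-bond donor seen in compound 1 but with a smaller group than (tert-butyl)amino, so the expected movement is a partial reversal of an at least 5.6-fold lower number from compound 1 to compound 2 (0.75 log units; beyond the scatter). The estimated step from compound 2 to compound 3 is therefore a 2.0-fold higher number from compound 2 to compound 3 (0.31 log units; beyond the scatter), toward a higher number. Compound 3 is expected to give 18 mg/kg in this assay. The estimated range for compound 3 runs from 6 mg/kg to 60 mg/kg, with a real chance that only a limit is reported.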

Compound 3, dose for half-maximal effect: 5 mg/kg
Compound 3: the middle estimate sits 3.6-fold (0.56 log units) above what was measured, outside the stated range (below it).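

In this assay, the step of a 1.8-fold lower number from compound 2 to compound 3 (0.25 log units; within the scatter) shows that cyclopropylamino and dimethylamino cannot be told apart on this aromatic carbon, although one group carries a hydrogen-bond donor and the other carries none. With the nitrogen hydrogen kept in both compounds, the step of an at least 10-fold lower number from compound 1 to compound 3 (1.00 log units; beyond the scatter) separates the effect of the group on that nitrogen from the presence of the donor, so the donor alone does not set the read-out in this pair. Compound 1 stands only as a limit, so the full size of that step stays unknown: the limit of > 50 mg/kg in this assay, at which 1 of the 3 values shown sits.

Open, from the compounds shown here alone, is whether a plain amino group, methylamino or isopropylamino would stay level with compound 2 and compound 3 or move toward compound 1. Also open, going by these compounds, is what chlorine or methoxy in place of the fluorine would do.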